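This account rests on a few compounds, and the source may have more. Where it says the series, first, only, none or still open, it means among the compounds named here.

Measured compounds:
compound 1 `C=C(Br)C(=O)Nc1cccc(-c2cn3nc(-c4ccc(F)cc4)sc3n2)c1`: 830 nM
compound 2 `C=C(Br)C(=O)Nc1cccc(-c2cn3nc(-c4ccc(OCC)cc4)sc3n2)c1`: 1400 nM

In a functional assay on CCRF-CEM cells (Homo sapiens) for inhibition, read by cell counting, with a stated time of 3 days (a lower number here means a stronger inhibitor, a higher number a weaker inhibitor), compound 2 gives 1400 nM and compound 1 gives 830 nM; the step of a 1.7-fold higher number from compound 1 to compound 2 (0.23 log units; within the scatter) lies within the scatter, so the two are not separated. Compound 3 `C=C(Br)C(=O)Nc1cccc(-c2cn3nc(Cc4ccc(Cl)cc4)sc3n2)c1` differs from compound 2 by 4-chlorobenzyl in place of 4-ethoxyphenyl on an aromatic carbon. Going by the values given here, the only measured step, between compound 1 and compound 2, concerns the substituent on the phenyl and does not cover the aryl-to-benzyl exchange, so no measured step bears on it directly. With no guidance beyond that, no change beyond the scatter is expected, a 1.2-fold lower number from compound 2 to compound 3 (0.07 log units; within the scatter). Compound 3 is therefore estimated at 1200 nM, in the range 400 nM to 4000 nM.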

Compound 3, half-maximal inhibitory concentration: 3300 nM
Compound 3: middle estimate off by 2.8-fold (0.44 log units), on the low side, within the range that was stated.
By their numbers in this assay, from the lowest: compounds 1 and 2 (each within the scatter of the next); then compound 3.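

In this assay, the exchange of an aryl group for 4-chlorobenzyl on the aromatic carbon next to the ring sulfur gives the first separation at this position. The step of a 2.4-fold higher number from compound 2 to compound 3 (0.37 log units; beyond the scatter) and the step of a 4.0-fold higher number from compound 1 to compound 3 (0.60 log units; beyond the scatter) both lie beyond the scatter and run the same way, while compound 1 and compound 2 remain unseparated. Nothing at hand accounts for this difference.

Going by these compounds, the exchange alters the methylene link and the ring substituent at once, so their separate shares stay open. Also open, on these data alone, is how an amine or a carboxylic acid on that phenyl ring, or a longer chain in place of the methylene link, would read in this assay.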